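Chloro in place of chloromethyl on the amide chain

The source may hold more compounds than are shown below. What is called first, only, known or untested is meant among the compounds shown, and "the series" means these compounds.

Compound 1 `Cn1cccc1-c1nc2cc(NC(=O)CCCl)ccc2[nH]1`: > 50000 nM
Compound 2 `Cc1ccc(-c2nc3cc(NC(=O)CCCl)ccc3[nH]2)cc1`: > 50000 nM
Compound 3 `O=C(CCCl)Nc1ccc2[nH]c(-c3ccc(Br)cc3)nc2c1`: 11300 nM

In a functional assay on HepG2 cells (Homo sapiens) for cytotoxicity, read by MTT assay, with a stated time of 72 h (on this read-out higher numbers stand for weaker inhibition and lower numbers for stronger inhibition), compound 1 gives only > 50000 nM, a limit of the assay rather than a number. Compound 1 thus sits at the limit of > 50000 nM in this assay, at which 2 of the 3 values shown sit. Compound 3, by contrast, gives a measured number, 11300 nM. The three measured steps, a step that the two limits leave unreadable from compound 1 to compound 2, an at least 4.4-fold lower number from compound 1 to compound 3 (0.64 log units; beyond the scatter) and an at least 4.4-fold lower number from compound 2 to compound 3 (0.64 log units; beyond the scatter), all change the aromatic group attached to the shared core; none of them touches the amide chain.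

Compound 4 `Cn1cccc1-c1nc2cc(NC(=O)CCl)ccc2[nH]1` differs from compound 1 by chloro in place of chloromethyl on a saturated chain carbon bound to a carbonyl carbon. For the measured compounds named here, since no measured step bears on this part of the molecule, neither a direction nor a size can be read from the data, and compound 4 is expected to remain near the limit, estimated at 35000 nM (between 8000 nM and 60000 nM), which would mean a step of an at least 1.4-fold lower number from compound 1 to compound 4 (0.15 log units; that floor lies within the scatter).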

Compound 4, half-maximal inhibitory concentration: 1800 nM
Beside the measured number, compound 4's estimate is 19-fold (1.29 log units) above it; measured number below the stated range.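

For the compounds shown here, the amide chain, which no earlier step touched, turns out to matter in this assay: going from 2-chloroethyl to chloromethyl gives an at least 27-fold lower number from compound 1 to compound 4 (1.44 log units; beyond the scatter). The earlier readable steps all changed the aromatic group, whereas here that group stays as it is and the chain change alone moves the number. This size is only a floor, because compound 1 carries a limit of the assay rather than a number: the limit of > 50000 nM in this assay, at which 2 of the 4 values shown sit.

From the compounds shown here alone, whether the same chain change would act alike with the aromatic groups of compound 2 and compound 3 stays open. So does the effect of an aminomethyl group or a longer chain in place of chloromethyl.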